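Where Compound 4 Is Expected to Stand

The compounds below may be only part of what the source reports. "The series", "measured", "known", "first", "only" and "open" are said of these compounds alone.

Compound 1 `Cc1cc(NC(=O)Nc2ncccc2C)c2ccccc2n1` is a urea built on a shared core. In an ADME assay on Raji cells (Homo sapiens) for cytotoxicity, with a stated time of 72 h (on this read-out higher numbers stand for an effect only at larger amounts of compound and lower numbers for an effect already at smaller amounts), compound 1 gives > 25000 nM, which is a limit of the assay and not a number. Compound 2 `Cc1cc(NC(=O)Nc2cc(Cl)cc(Cl)c2)c2ccccc2n1` shares this core, and in this assay compound 2 gives > 25000 nM, also a limit. Compound 3 `Cc1cc(NC(=O)Nc2cccc([N+](=O)[O-])c2)c2ccccc2n1` is the third member, and in this assay compound 3 gives > 25000 nM, again a limit. So compound 1 sits where every measured compound sits, at the limit of > 25000 nM in this assay, at which 3 of the 3 values shown sit, and no step between two numbers is available.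

Compound 4 `Cc1cc(NC(=O)Nc2ccc(Cl)cc2)c2ccccc2n1` keeps the core and differs from compound 1 in one place: 4-chlorophenyl in place of 3-methylpyridin-2-yl on an amide-type nitrogen. Compound 2 carries chlorine on a phenyl ring at this same place and still reaches only the limit, so no step beyond the usual scatter is expected from compound 1 to compound 4 a number no higher from compound 1 to compound 4 (the limit leaves the size open). Compound 4 is therefore estimated at 25000 nM, with a range from 8000 nM to 80000 nM, most likely reported as a limit.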

Compound 4, half-maximal effective concentration: > 25000 nM
Compound 4: a limit, no number; the forecaster's own chance of this, stated with the estimate: 85%; the middle value sits exactly at the limit.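

Among the compounds shown here, compound 1 and compound 4 both stop at a limit of the assay and not at a number, so no step between them can be read. The compounds shown leave open where any of them would give a real number in this assay, since all sit at one value: the limit of > 25000 nM in this assay, at which 4 of the 4 values shown sit.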